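Methyl on the Ring Nitrogen: From Compound 3 to Compound 4

This account rests on a few compounds, and the source may have more. Where it says the series, first, only, none or still open, it means among the compounds named here.

Measured so far in an assay on membranes from brain for displacement of a labelled ligand from adenosine receptor A1 (Cavia porcellus); a higher number here means a weaker inhibitor, a lower number a stronger inhibitor:
- compound 1, `CCCn1c(=O)n(C)c(=O)c2[nH]cnc21`, gives 1900 nM
- compound 2, `CCCn1c(=O)n(CC)c(=O)c2[nH]cnc21`, gives 1400 nM
- compound 3, `CCCCn1c(=O)[nH]c(=O)c2[nH]cnc21`, gives 21400 nM

Compound 3 stands with the highest number of the three, above compound 1 by a margin beyond the scatter and further still from compound 2. Compound 4, `CCCCn1c(=O)n(C)c(=O)c2[nH]cnc21`, is not yet measured. It differs from compound 3 in one place: methyl in place of hydrogen on an aromatic nitrogen.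

Going by the values given here, only one measured step exists, a 1.4-fold lower number from compound 1 to compound 2 (0.13 log units; within the scatter), and it concerns a methyl on a chain carbon, not on the ring nitrogen, so it bears on the present change only loosely. Among the compounds with values here, no compound pair differs solely by the group that enters here. What can be said is that compound 1, which carries a methyl on that ring nitrogen and a propyl group, gives 1900 nM, while compound 3 with hydrogen there and a butyl group gives 21400 nM; the two differ in two places at once.

Taking compound 1 as the nearer guide, compound 4 is expected to land near compound 1, which would mean an estimated step of an 8.6-fold lower number from compound 3 to compound 4 (0.93 log units; beyond the scatter) in this assay. The estimate for compound 4 is 2500 nM, within a range from 800 nM to 8000 nM.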

Compound 4, inhibition constant: 1900 nM
Compound 4: middle estimate off by 1.3-fold (0.12 log units), on the high side; the measured number falls inside the stated range.
By their numbers in this assay, from the lowest: compounds 2, 1 and 4 (each within the scatter of the next); then compound 3.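

In this assay, the ring nitrogen gives its first reading from a single change: methyl in place of hydrogen on an aromatic nitrogen produces an 11-fold lower number from compound 3 to compound 4 (1.05 log units; beyond the scatter) and thus a large step beyond the scatter, which the earlier comparison of compounds differing in two places could not isolate. The neighbouring changes behave quite differently, as methyl in place of hydrogen on a saturated chain carbon, three bonds along the chain from an aromatic nitrogen, gives no change at the digits printed from compound 1 to compound 4 (within the scatter) and the further carbon on the group at the ring nitrogen gives a 1.4-fold lower number from compound 1 to compound 2 (0.13 log units; within the scatter), both within the scatter, so among these compounds only going from hydrogen to methyl on that ring nitrogen separates one compound from the others. Nothing available accounts for the size of this step.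

As far as these compounds go, whether the same step would appear with a propyl group in place of the butyl group remains open, since only the butyl pair shows it. Also open, from the compounds shown here alone, is whether a chain longer than ethyl on the ring nitrogen, or an amine or a carboxylic acid at the end of such a chain, would leave the number where it stands or move it.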